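The source may report more compounds than this note shows. Statements on the series, on what has been measured and on what is new or still open speak of the compounds shown alone.

Working notes on the series. In a functional assay on HEK293 cells for negative allosteric modulation of metabotropic glutamate receptor 2 (Rattus norvegicus), read by calcium flux, with a stated time of 2.5 min (on this read-out higher numbers stand for weaker inhibition and lower numbers for stronger inhibition), compound 1 `COc1ccc(C#Cc2ccc(C(=O)N3CC[C@@H](O)C3)cc2)cc1` gives > 30000 nM, which is a limit of the assay and not a number. Compound 2 `COc1ccc(C#Cc2ccc(C(=O)N3CC4CCC(O)C4C3)cc2)cc1` gives in this assay > 30000 nM, again a limit and not a number. The step that the two limits leave unreadable from compound 1 to compound 2 therefore cannot be read, since both of its ends sit at the same limit (the limit of > 30000 nM in this assay, at which 2 of the 2 values shown sit); compound 2 thus stands only at the limit, with no number to place it against compound 1.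

Compound 3 `COc1ccc(C#Cc2ccc(C(=O)N3CCCC(C)(O)C3)cc2)cc1` is not yet measured. Relative to compound 2 the change is a group of 8 heavy atoms (6 carbon, 1 nitrogen, 1 oxygen; one six-membered non-aromatic ring with 1 hetero atom) in place of a group of 9 heavy atoms (7 carbon, 1 nitrogen, 1 oxygen; one five-membered non-aromatic ring of carbon only, one five-membered non-aromatic ring with 1 hetero atom), on a carbonyl carbon. Among the measured compounds shown here, no measured step gives a readable size that bears on this change; the one step available is unreadable. On that basis no shift beyond the scatter is expected in this assay, and compound 3 is expected to sit likewise at or around the limit, a step that the limit leaves unreadable from compound 2 to compound 3. The estimate for compound 3 in this assay is 40000 nM, within 10000 nM to 150000 nM.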

Compound 3, half-maximal inhibitory concentration: > 30000 nM
Compound 3 gave a limit, no number (the forecaster's own chance of this, stated with the estimate: 75%); the middle value is on the limit's open side.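

No step among compound 1, compound 2 and compound 3 can be read in this assay, since each gives a limit of the assay and not a number: the limit of > 30000 nM in this assay, at which 3 of the 3 values shown sit.

The compounds shown leave open how these three rank against one another, and which group on the carbonyl carbon, if any, gives a numerical half-maximal inhibitory concentration.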